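The source may hold more compounds than are shown below. What is called first, only, known or untested is meant among the compounds shown, and "the series" means these compounds.

In a functional assay on HepG2 cells (Homo sapiens) for antiproliferative activity, read by MTT assay, with a stated time of 48 h (on this read-out lower numbers stand for stronger inhibition and higher numbers for weaker inhibition), compound 1, `CCn1c(C(=O)NCC#N)ccc1C(CC)(CC)c1ccc(OCCC(O)(CC)CC)c(C)c1`, gives > 50000 nM, which is a limit and not a number. Compound 2, `CCOc1ccc(NC(=O)c2ccc(C(CC)(CC)c3ccc(OCCC(O)(CC)CC)c(C)c3)n2CC)cc1`, gives > 50000 nM, again a limit. Compound 3, `CCC(C)C(NC(=O)c1ccc(C(CC)(CC)c2ccc(OCCC(O)(CC)CC)c(C)c2)n1CC)C(=O)OC`, gives > 50000 nM, also a limit. The three compounds therefore all stand at the limit of > 50000 nM in this assay, at which 3 of the 3 values shown sit, and compound 3 has no measured potency of its own to start from.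

Compound 4, `CCC(C)C(NC(=O)c1ccc(C(CC)(CC)c2ccc(OCCC(O)(CC)CC)c(C)c2)n1CC)C(=O)O`, differs from compound 3 by hydrogen in place of methyl on an oxygen next to a carbonyl group, so that methoxycarbonyl becomes carboxy. The measured steps offer little guidance on this change. They are a step that the two limits leave unreadable from compound 1 to compound 2, a step that the two limits leave unreadable from compound 1 to compound 3 and a step that the two limits leave unreadable from compound 2 to compound 3, and each exchanges a group on an amide-type nitrogen. None of them touches methoxycarbonyl or carboxy, and none has a readable size.

The data therefore support no expected direction, and the most likely outcome is that compound 4 remains at the same limit as the other three. On that basis, the expected change is a number no higher from compound 3 to compound 4 (the limit leaves the size open). For compound 4, the estimated value is 50000 nM, with an expected range from 20000 nM to 100000 nM.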

Compound 4, half-maximal inhibitory concentration: 2620 nM
Estimate against measurement, compound 4: 19-fold (1.28 log units) above; measured number below the stated range.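

In this assay, hydrogen in place of methyl on an oxygen next to a carbonyl group, which turns methoxycarbonyl into carboxy, gives an at least 19-fold lower number from compound 3 to compound 4 (1.28 log units; beyond the scatter), and compound 4 is the only compound shown to leave the limit: the limit of > 50000 nM in this assay, at which 3 of the 4 values shown sit.

The same holds against the two other groups on the amide-type nitrogen, with 1-carboxy-2-methylbutyl giving an at least 19-fold lower number from compound 2 to compound 4 (1.28 log units; beyond the scatter) and an at least 19-fold lower number from compound 1 to compound 4 (1.28 log units; beyond the scatter). The earlier compounds shown here, whose mutual steps cannot be read, showed only that cyanomethyl, 4-ethoxyphenyl and the methyl ester group all left the read-out at its limit, whereas this result shows that the read-out responds to a change at this oxygen, with the free carboxy form giving a measurable number and its methyl ester not.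

Compound 4 is the only carboxylic acid shown, so it remains open whether the rest of the 1-carboxy-2-methylbutyl group matters or whether a shorter chain carrying the same carboxy would serve equally. On these data alone, it is also open whether a primary amide or an amine in place of carboxy would keep a measurable number in this assay.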